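Working notes on a shared-core amide series

The source may report more compounds than this note shows. Statements on the series, on what has been measured and on what is new or still open speak of the compounds shown alone.

Measured so far in a functional assay on MCF7 cells (Homo sapiens) for cytotoxicity, read by MTT assay, with a stated time of 24 h, tested at 32 ug/mL; on this read-out lower numbers stand for a weaker effect and higher numbers for a stronger effect at the one concentration tested:
compound 1 `Cn1c(-c2ccc(NC(=O)CSc3nc4ccccc4o3)cc2)nc(-c2ccccc2)c1-c1ccccc1`: 71.5%
compound 2 `Cn1c(-c2ccc(NC(=O)CSc3nc4cc(Cl)ccc4o3)cc2)nc(-c2ccccc2)c1-c1ccccc1`: 59.7%
compound 3 `Cn1cnnc1SCC(=O)Nc1ccc(-c2nc(-c3ccccc3)c(-c3ccccc3)n2C)cc1`: 89.2%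

Compound 1 stands second highest of the three numbers. Compound 2 sits below it by a number 11.8 percentage points lower from compound 1 to compound 2 (beyond the scatter), compound 3 above it by a number 17.7 percentage points higher from compound 1 to compound 3 (beyond the scatter), and from compound 2 to compound 3 the rise is a number 29.5 percentage points higher from compound 2 to compound 3 (beyond the scatter).

The next compound, compound 4 `Cn1c(-c2ccc(NC(=O)CN3CCN(c4ccccc4)CC3)cc2)nc(-c2ccccc2)c1-c1ccccc1`, differs from compound 1 by 4-phenylpiperazin-1-yl in place of (1,3-benzoxazol-2-yl)sulfanyl on a saturated chain carbon bound to a carbonyl carbon. For the measured compounds named here, no measured step removes the sulfur link itself; the nearest comparisons are the swaps on the sulfur, where a smaller heteroaryl gave a number 17.7 percentage points higher from compound 1 to compound 3 (beyond the scatter) and a number 29.5 percentage points higher from compound 2 to compound 3 (beyond the scatter), both modest rises. Those steps bear only loosely on compound 4, since here the whole (1,3-benzoxazol-2-yl)sulfanyl group leaves and 4-phenylpiperazin-1-yl enters. A modest step is therefore expected for a number 0.5 percentage points higher from compound 1 to compound 4 (within the scatter), with the direction uncertain and a wide range allowed. For compound 4 the estimate in this assay is 72%, between 52% and 90%.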

Compound 4, a percentage reported as activity, at one concentration (the size of the read-out at that concentration, not a potency): 63.6%
Compound 4: middle estimate off by 8.4 percentage points, on the high side; low and high end bracket the measured number.
By their numbers in this assay, from the lowest: compounds 2, 4 and 1 (each within the scatter of the next, the first and the last beyond it); then compound 3.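

In this assay, the saturated chain carbon bound to a carbonyl carbon accepts a group without sulfur: 4-phenylpiperazin-1-yl in place of (1,3-benzoxazol-2-yl)sulfanyl gives a number 7.9 percentage points lower from compound 1 to compound 4 (within the scatter), and in place of (5-chloro-1,3-benzoxazol-2-yl)sulfanyl it gives a number 3.9 percentage points higher from compound 2 to compound 4 (within the scatter). Only the (4-methyl-4H-1,2,4-triazol-3-yl)sulfanyl group stands apart, with a number 25.6 percentage points lower from compound 3 to compound 4 (beyond the scatter), so the sulfur link alone does not set the number in this series. Nothing at hand explains these steps.

Open, on these data alone, is what the phenyl and the piperazine ring each contribute, which 4-methylpiperazin-1-yl or morpholin-4-yl at this carbon could separate. The single-concentration read-out also leaves the potency of all four compounds undefined.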